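This account rests on a few compounds, and the source may have more. Where it says the series, first, only, none or still open, it means among the compounds named here.

Measured so far in a functional assay on A2780 cells (Homo sapiens) for antiproliferative activity, read by MTT assay, with a stated time of 3 days; on this read-out lower numbers stand for stronger inhibition and higher numbers for weaker inhibition:

compound 1 `COC1(c2ccc(Br)cc2)SC=C(C)n2c1noc2=O`: 148000 nM
compound 2 `COC1(c2ccc(Cl)cc2)SC=C(C)n2c1noc2=O`: 166000 nM
compound 3 `O=c1onc2n1C=CSC2(O)c1ccccc1`: a limit of the assay, > 100000 nM

In this assay compound 1 gives 148000 nM and compound 2 gives 166000 nM. For compound 3 the assay reports no number but only its limit, > 100000 nM; this is the limit of > 100000 nM in this assay, at which 1 of the 3 values shown sits. Of the two real numbers, compound 2 carries the larger one, yet it sits within the scatter of compound 1: a 1.1-fold higher number from compound 1 to compound 2 (0.05 log units; within the scatter), a swap of one halogen for another on the aromatic ring that leaves the potency unchanged.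

Compound 4 `CCCCCOC1(c2ccc(Cl)cc2)SC=C(C)n2c1noc2=O` has not yet been measured. It differs from compound 2 in one place: butyl in place of hydrogen on a saturated chain carbon bound to an oxygen on a saturated carbon. For the measured compounds named here, no measured step touches this part of the molecule. Going by the values given here, the only step known, from compound 1 to compound 2, alters the halogen on the aromatic ring and lies within the scatter, so it gives no guidance on lengthening the chain on the oxygen. In the absence of such evidence, compound 4 is expected to land near compound 2, with a wide range: the estimate for compound 4 in this assay is 90000 nM, between 20000 nM and 300000 nM. This estimate means a step of a 1.8-fold lower number from compound 2 to compound 4 (0.27 log units; within the scatter), which is expected to stay close to the scatter.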

Compound 4, half-maximal inhibitory concentration: > 100000 nM
Compound 4: a limit, no number (the forecaster's own chance of this, stated with the estimate: 35%); middle value at least 1.1-fold (0.04 log units) from the limit.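

In this assay, for the compounds shown here, compound 4 gives > 100000 nM as a limit and not a number, so no step from compound 2 to compound 4 can be read. The compounds shown leave open whether pentyloxy in place of methoxy changes the result in this assay at all and, if it does, by how much.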